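This account rests on a few compounds, and the source may have more. Where it says the series, first, only, none or still open, it means among the compounds named here.

Three compounds share one core and differ only in the group on a ring amine nitrogen. In a functional assay on A549 cells (Homo sapiens) for antiproliferative activity, read by MTT assay, with a stated time of 72 h (on this read-out lower numbers stand for stronger inhibition and higher numbers for weaker inhibition), compound 1 `CN1CCN(C(=S)SCc2ccc3nc(N)nc(N)c3c2)CC1` carries methyl and gives 9200 nM as its value, compound 2 `Nc1nc(N)c2cc(CSC(=S)N3CCN(C4CCCCC4)CC3)ccc2n1` carries cyclohexyl and gives 4710 nM as its value, and compound 3 `Nc1nc(N)c2cc(CSC(=S)N3CCN(c4ccccc4)CC3)ccc2n1` carries phenyl and gives 2970 nM as its value. Compound 3 stands clearly apart only from compound 1, as the record shows a 3.1-fold lower number from compound 1 to compound 3 (0.49 log units; beyond the scatter) for that swap. It cannot be told apart from compound 2, given a 1.6-fold lower number from compound 2 to compound 3 (0.20 log units; within the scatter) between them.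

The next structure, compound 4 `Nc1nc(N)c2cc(CSC(=S)N3CCN(c4ccc(O)cc4)CC3)ccc2n1`, turns the phenyl of compound 3 into 4-hydroxyphenyl, a change counted as hydroxy in place of hydrogen on an aromatic carbon and nothing else. Among the compounds with values here, no measured compound carries a hydroxy, so no step tests this change directly. Within the data shown here, the only guides are the swaps of the whole group at this same nitrogen, which gave a 2.0-fold lower number from compound 1 to compound 2 (0.29 log units; within the scatter) and the modest step from methyl to phenyl already noted. These steps are small, and none of them points to a direction for a hydroxy. The expected change in this assay is therefore none beyond the scatter, estimated as a 1.0-fold higher number from compound 3 to compound 4 (0.00 log units; within the scatter) here. For compound 4 the estimate is 3000 nM with an expected range of 1100 nM to 8000 nM for the measurement.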

Compound 4, half-maximal inhibitory concentration: 4210 nM
Compound 4: the middle estimate sits 1.4-fold (0.15 log units) below what was measured; the measured number falls inside the stated range.
By their numbers in this assay, from the lowest: compounds 3, 4, 2 and 1 (each within the scatter of the next, the first and the last beyond it).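

In this assay the hydroxy can now be judged directly: the record gives a 1.4-fold higher number from compound 3 to compound 4 (0.15 log units; within the scatter) for this one change, so adding a hydroxy on this aromatic carbon gives a number that cannot be told apart from that of plain phenyl. Compared across the whole group on the ring nitrogen, 4-hydroxyphenyl also cannot be told apart from cyclohexyl, with a 1.1-fold lower number from compound 2 to compound 4 (0.05 log units; within the scatter) on record, while it does stand clear of methyl, with a 2.2-fold lower number from compound 1 to compound 4 (0.34 log units; beyond the scatter) on record, a modest separation of the kind phenyl already showed. No separate measurement accompanies these numbers to explain them.

Within the data shown here, only one group has been placed on this phenyl, so the series does not show whether a methoxy, an amine or a carboxylic acid on the same aromatic carbon would also leave the number within the scatter or would shift it clearly. Going by these compounds, it also remains open whether a longer chain in place of the methyl, or a benzyl on the ring nitrogen, would fall among compound 2, compound 3 and compound 4 or away from them.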